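Trading the Hydroxyethoxy Ester for a Butyl Ketone

The compounds below may be only part of what the source reports. "The series", "measured", "known", "first", "only" and "open" are said of these compounds alone.

Three measured compounds share one core and differ only in the group attached to the carbonyl carbon. In an assay on cells for agonist activity at vitamin D3 receptor (Homo sapiens), read by microscopy (on this read-out lower numbers stand for an effect already at smaller amounts and higher numbers for an effect only at larger amounts of compound), compound 1 `CCn1cc(C(CC)(CC)c2ccc(C#CC(O)(CC)CC)c(C)c2)cc1C(=O)NCC(=O)OC` gives 288 nM, compound 2 `CCn1cc(C(CC)(CC)c2ccc(C#CC(O)(CC)CC)c(C)c2)cc1C(=O)NCCCN(C)C` gives 142 nM, and compound 3 `CCn1cc(C(CC)(CC)c2ccc(C#CC(O)(CC)CC)c(C)c2)cc1C(=O)OCCO` gives 12.6 nM. Compound 3 stands lowest of the three: its nearest neighbour is compound 2, and the step of an 11-fold lower number from compound 2 to compound 3 (1.05 log units; beyond the scatter) is large, while a 23-fold lower number from compound 1 to compound 3 (1.36 log units; beyond the scatter) is larger still. The step of a 2.0-fold lower number from compound 1 to compound 2 (0.31 log units; beyond the scatter) between the two amide-type compounds is modest by comparison.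

Compound 4 `CCCCC(=O)c1cc(C(CC)(CC)c2ccc(C#CC(O)(CC)CC)c(C)c2)cn1CC` is not yet measured. Relative to compound 3 it carries butyl in place of 2-hydroxyethoxy on a carbonyl carbon. Both known changes at the carbonyl carbon swapped an amide-type nitrogen substituent for the 2-hydroxyethoxy group, and both lowered the number by a large step. Within the data shown here, neither tells how the donor and acceptors counted in that group matter once all of them are gone, since no measured compound lacks them. The author therefore expects compound 4 to give a higher number than compound 3, by a step of about a 4.0-fold higher number from compound 3 to compound 4 (0.60 log units; beyond the scatter) in this assay, beyond the scatter but smaller than the measured steps. The estimate for compound 4 is 50 nM, with a range from 12 nM to 250 nM.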

Compound 4, half-maximal effective concentration: > 50 nM
Compound 4 was reported as a limit; the forecaster's own chance of this, stated with the estimate: 5%; the middle value sits exactly at the limit.
By their numbers in this assay, from the lowest: compound 3; then compound 2; then compound 1.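

In this assay compound 4 is reported as > 50 nM, which is a limit of the assay and not a number. Even so, the position now has a reading for an all-carbon group, butyl, with 0 hydrogen-bond donors and 0 hydrogen-bond acceptors, which the earlier compounds, all carrying a heteroatom-bearing group on the carbonyl carbon, could not give: the change from 2-hydroxyethoxy to butyl gives an at least 3.9-fold higher number from compound 3 to compound 4 (0.59 log units; beyond the scatter), so the low number of compound 3 does not survive this replacement. The steps to compound 4 from the two amide-type compounds cannot be read, so the result fixes only one side of the butyl ketone's standing, and how far the number rises remains unknown: the limit of > 50 nM in this assay, at which 1 of the 4 values shown sits.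

The compounds shown leave open whether the hydroxyl or the ester oxygen of the 2-hydroxyethoxy group accounts for the difference, since both leave together in this one change. A 4-hydroxybutyl group or a 2-methoxyethoxy group on the same carbonyl carbon would separate the two, and a shorter chain such as ethyl would show whether the length of the butyl matters.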